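The source may report more compounds than this note shows. Statements on the series, on what has been measured and on what is new or still open speak of the compounds shown alone.

In a functional assay on MCF7 cells (Homo sapiens) for antiproliferative activity, read by MTT assay, with a stated time of 48 h (on this read-out higher numbers stand for weaker inhibition and lower numbers for stronger inhibition), compound 3 `C=C(c1cc(OC)c(OC)c(OC)c1)c1ccc(OC)c(O)c1NC(C)=O` gives 270 nM, level with compound 2 `COc1ccc(C(=O)c2cc(OC)c(OC)c(OC)c2)c(NC(=O)CN)c1` at 270 nM, while compound 1 `CNCC(=O)Nc1cc(OC)ccc1C(=O)c1cc(OC)c(OC)c(OC)c1` gives 550 nM. Compound 4 `C=C(c1cc(OC)c(OC)c(OC)c1)c1ccc(OC)c(O)c1NC(=O)COCC` differs from compound 3 by ethoxy in place of hydrogen on a saturated chain carbon bound to a carbonyl carbon, which turns acetamido into ((ethoxymethyl)carbonyl)amino. Among the compounds with values here, only one measured step bears on this, and only loosely: a 2.0-fold lower number from compound 1 to compound 2 (0.31 log units; beyond the scatter), with hydrogen in place of methyl on an amine nitrogen. Within the data shown here, that step lies on the core of compound 1, and no measured step tests the ethoxy change itself. Extra substitution on the chain therefore points weakly toward a higher number in this assay. The expected change is a 2.2-fold higher number from compound 3 to compound 4 (0.35 log units; beyond the scatter), a modest step toward weaker inhibition. For compound 4 the estimated value is 600 nM, with an expected range of 200 nM to 1800 nM.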

Compound 4, half-maximal inhibitory concentration: 1050 nM
For compound 4 the middle estimate is 1.8-fold (0.24 log units) below the measured one; low and high end bracket the measured number.
By their numbers in this assay, from the lowest: compounds 2 and 3 (each within the scatter of the next); then compounds 1 and 4 (each within the scatter of the next).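

In this assay, ethoxy in place of hydrogen on a saturated chain carbon bound to a carbonyl carbon gives a 3.9-fold higher number from compound 3 to compound 4 (0.59 log units; beyond the scatter). Within the data shown here, this is the first direct reading at this position, and it shows that the carbon is sensitive to this added substitution on the core of compound 3. No measured property bears on why the step has this size.

On these data alone, whether the higher number follows from the chain's length or from its ether oxygen stays open, and a propyl group on the same carbon would separate the two. As far as these compounds go, an amine at this carbon on the core of compound 3 also remains open.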